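Swapping propargyloxy for nitro: cytotoxicity expected to change little

The compounds below may be only part of what the source reports. "The series", "measured", "known", "first", "only" and "open" are said of these compounds alone.

Of the compounds shown here, three have so far been tested in an ADME assay on RAW264.7 cells (Mus musculus) for cytotoxicity, read by MTT assay, with a stated time of 48 h; a lower number here means that less compound is tolerated, a higher number that more compound is tolerated. Compound 1 `C#CCOc1ccc(-c2noc(N(CC#C)C3CCCCC3)n2)cc1` gives 101 ug/mL and stands second highest of the three. Compound 2 `CC(=O)OC[C@H]1O[C@H](OC[C@@H](CN=[N+]=[N-])OC(C)=O)C=C[C@@H]1OC(C)=O` gives 106 ug/mL, a number within the scatter of compound 1, so no order between the two can be read. Compound 3 `CC(=O)OC[C@H]1O[C@H](OC[C@@H](Cn2cc(CN(c3nc(-c4ccc(Br)cc4)no3)C3CCCCC3)nn2)OC(C)=O)C=C[C@@H]1OC(C)=O` gives 39.1 ug/mL, a lower number beyond the scatter, so less of compound 3 is tolerated than of compound 1.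

Compound 4 `C#CCN(c1nc(-c2ccc([N+](=O)[O-])cc2)no1)C1CCCCC1` has not been measured. It differs from compound 1 in one place: nitro in place of propargyloxy on an aromatic carbon, on an aromatic carbon of a six-membered aromatic ring of carbon only. Within the data shown here, no measured pair shows a step of this kind, so the expectation rests on compound 1 alone. The step from compound 1 to compound 4 is expected to be a 1.2-fold lower number from compound 1 to compound 4 (0.07 log units; within the scatter), lying within the scatter. Compound 4 is estimated at 85 ug/mL, with a range from 40 ug/mL to 170 ug/mL.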

Compound 4, half-maximal cytotoxic concentration: 26.7 ug/mL
Estimate against measurement, compound 4: 3.2-fold (0.50 log units) above, and the stated range ends above it.
By their numbers in this assay, from the lowest: compounds 4 and 3 (each within the scatter of the next); then compounds 1 and 2 (each within the scatter of the next).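

In this assay, nitro in place of propargyloxy on this aromatic carbon, para to a large group, gives a 3.8-fold lower number from compound 1 to compound 4 (0.58 log units; beyond the scatter), so less compound is tolerated and this position is not indifferent to the group it carries. Among these compounds, this is the first single-place change in the set, and it shows that a swap at this position alone can move the number beyond the scatter. No measurement shown here accounts for the size of this step.

From the compounds shown here alone, how an amine, a carboxylic acid or a longer chain at this position would read remains open.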